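Swapping methoxy for chloro on the outer ring

The source may report more compounds than this note shows. Statements on the series, on what has been measured and on what is new or still open speak of the compounds shown alone.

Two benzamide-type compounds with a free aromatic amine have been tested in a functional assay on A-375 cells (Homo sapiens) for inhibition, read by CCK-8 assay, with a stated time of 72 h, tested at 8 uM; a lower number here means less inhibition of growth, a higher number more inhibition of growth at the concentration tested. Compound 1, `COc1ccc(SCc2ccc(C(=O)Nc3ccccc3N)cc2)cc1`, carries a methoxy group on its outermost ring. In this assay, within the data shown here, compound 1 gives 81.8%, the higher of the two numbers measured so far. Compound 2, `Nc1ccccc1NC(=O)/C=C/c1ccc(CSc2cccc3ccccc23)cc1`, which has a longer linker and a different outer ring system, gives 36% in this assay, a number that lies well below compound 1, beyond the usual scatter. As the two differ in more than one place, their gap cannot be pinned on a single change.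

The unmeasured compound 3, `Nc1ccccc1NC(=O)c1ccc(CSc2ccc(Cl)cc2)cc1`, differs from compound 1 in one place only: chloro in place of methoxy on an aromatic carbon. Cut one bond further out, the change reads 4-methoxyphenyl to 4-chlorophenyl. Among the measured compounds shown here, no measured pair with this exact change exists here, so its effect is unknown. Given that the rest of the molecule is unchanged and compound 1 gives 81.8%, the expected step of a number 9.8 percentage points lower from compound 1 to compound 3 (within the scatter) is small, most likely a slight fall that stays near the scatter. Compound 3 is therefore estimated at 72%, within a range of 45% to 90%.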

Compound 3, percent growth inhibition at one concentration: 48.6%
Estimate against measurement, compound 3: 23.4 percentage points above; the range from low to high includes it.
By their numbers in this assay, from the lowest: compound 2; then compound 3; then compound 1.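

Chloro in place of methoxy on the outer ring gives a number 33.2 percentage points lower from compound 1 to compound 3 (beyond the scatter) in this assay. Among these compounds, compounds 1 and 2 differ in more than one place, so this is the first gap here that can be tied to a single change, and it shows that the group on this aromatic carbon, para to a large group, is not a neutral choice: with the rest of the molecule unchanged, this one swap alone moves growth inhibition at the concentration tested by more than the usual scatter. Nothing available here explains why this swap has an effect of this size.

One pair cannot show whether the drop comes from losing methoxy or from gaining chloro, nor whether a hydroxy group, a methyl group or an amine at the same place would fall nearer to compound 1 or to compound 3. From the compounds shown here alone, it also remains open whether the same swap would produce a step of similar size on a different core, such as one with a longer linker.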